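The source may report more compounds than this note shows. Statements on the series, on what has been measured and on what is new or still open speak of the compounds shown alone.

Measured compounds:
- compound 1 `COc1cc(/C=N/NC(=O)CCN2CCN(c3ccnc4cc(Cl)ccc34)CC2)ccc1O` gives 9400 nM in an ADME assay on cells (Splenocyte, Mus musculus, strain BALB/c) for cytotoxicity, read by thymidine incorporation, with a stated time of 24 h; a higher number here means a weaker inhibitor, a lower number a stronger inhibitor
- compound 2 `COc1cc(/C=N/NC(=O)CCN2CCN(c3ccnc4cc(Cl)ccc34)CC2)ccc1OC(C)C` gives 8800 nM in this assay
- compound 3 `O=C(CCN1CCN(c2ccnc3cc(Cl)ccc23)CC1)N/N=C/c1ccccc1` gives 300 nM in this assay

Compound 3 holds the lowest number of the three, with the nearest measured value being a 29-fold lower number from compound 2 to compound 3 (1.47 log units; beyond the scatter) away, and the furthest being a 31-fold lower number from compound 1 to compound 3 (1.50 log units; beyond the scatter) away. Both steps onto compound 3 are large and run in the same direction; the step of a 1.1-fold lower number from compound 1 to compound 2 (0.03 log units; within the scatter) is within the scatter.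

Compound 4 `O=C(CCN1CCN(c2ccnc3cc(Cl)ccc23)CC1)N/N=C/c1ccc([N+](=O)[O-])cc1` is not yet measured. The change is nitro in place of hydrogen on an aromatic carbon. All three measured steps concern substituents on the same six-membered ring of carbon only, so they bear on this step directly: stripping that ring of its hydroxy and methoxy groups lowered the number strongly, and exchanging hydrogen for isopropyl on the oxygen left it unchanged. Going by the values given here, no measured step places a nitro group on this ring, so the direction for compound 4 is uncertain. A moderate rise in the number for compound 4 is expected, as a step of a 2.3-fold higher number from compound 3 to compound 4 (0.37 log units; beyond the scatter) in this assay. Compound 4 is estimated at 700 nM, with a range from 150 nM to 3500 nM.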

Compound 4, half-maximal inhibitory concentration: 12100 nM
Compound 4: middle estimate off by 17-fold (1.24 log units), on the low side, and the stated range ends below it.
By their numbers in this assay, from the lowest: compound 3; then compounds 2, 1 and 4 (each within the scatter of the next).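

In this assay, one nitro group on the aromatic carbon para to a large group is enough for a large step, a 40-fold higher number from compound 3 to compound 4 (1.61 log units; beyond the scatter), so the low number of compound 3 does not carry over to every simple ring at this position. The 4-nitrophenyl ring matches both oxygen-bearing rings, with a 1.3-fold higher number from compound 1 to compound 4 (0.11 log units; within the scatter) and a 1.4-fold higher number from compound 2 to compound 4 (0.14 log units; within the scatter), both within the scatter; among these four compounds only the unsubstituted phenyl of compound 3 stands apart. Nothing available accounts for this behaviour.

As far as these compounds go, it remains open whether a methyl group, a fluorine atom or an amino group on the same aromatic carbon would stay close to compound 3 at 300 nM or join the other three. Also open, from the compounds shown here alone, is whether a nitro group on another carbon of this ring would give the same step.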